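A few compounds are considered here, and "the series" means these few. Any claim that something is new, unique, unknown or untested is made for them only; others in the source may bear on it.

The measured compounds in an assay on isolated protein for binding affinity to histamine H2 receptor (Homo sapiens); a lower number here means a stronger inhibitor, a higher number a weaker inhibitor:

Compound 1, `O=C(c1ccc(OCCCN2CC[C@H](NS(=O)(=O)c3ccc(Br)cc3)C2)cc1)C1CC1`: 290 nM
Compound 2, `O=C(c1ccc(OCCCN2CC[C@H](NS(=O)(=O)c3ccccc3F)C2)cc1)C1CC1`: 1550 nM
Compound 3, `CC(=O)c1ccc(OCCCN2CC[C@H](NC(=O)c3cccnc3)C2)cc1`: 3500 nM

Compound 1 stands lowest of the three numbers in this assay. The nearest value is that of compound 2, where the step of a 5.3-fold higher number from compound 1 to compound 2 (0.73 log units; beyond the scatter) comes from placing 2-fluorophenyl in place of 4-bromophenyl on the sulfonyl sulfur. Compound 3, which carries a different acyl group and an amide rather than a sulfonamide, gives a still higher number, and its gap to compound 1 lies beyond the scatter.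

Compound 4, `CCc1ccc(S(=O)(=O)N[C@H]2CCN(CCCOc3ccc(C(=O)C4CC4)cc3)C2)cc1`, differs from compound 1 by ethyl in place of bromo on an aromatic carbon, so that 4-bromophenyl becomes 4-ethylphenyl on the same sulfonyl sulfur. Going by the values given here, the only measured step that bears on it is the one from compound 1 to compound 2, which also altered this aryl group and raised the number modestly. Among the compounds with values here, no measured pair exchanges bromo for ethyl, and the two groups are counted alike in donors, acceptors and charge.

The step of a 1.4-fold higher number from compound 1 to compound 4 (0.14 log units; within the scatter) is therefore expected to be small, leaning slightly toward a higher number but possibly not beyond the scatter. Compound 4 is estimated at 400 nM in this assay, within a range of 150 nM to 1100 nM.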

Compound 4, inhibition constant: 330 nM
Compound 4: the middle estimate sits 1.2-fold (0.08 log units) above what was measured; low and high end bracket the measured number.
By their numbers in this assay, from the lowest: compounds 1 and 4 (each within the scatter of the next); then compound 2; then compound 3.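

In this assay, ethyl in place of bromo on an aromatic carbon gives a 1.1-fold higher number from compound 1 to compound 4 (0.06 log units; within the scatter) and so leaves the number unchanged within the scatter, even though the group entering has two heavy atoms where the one leaving has one. The other new comparison, 4-ethylphenyl in place of 2-fluorophenyl on the sulfonyl sulfur, gives a 4.7-fold lower number from compound 2 to compound 4 (0.67 log units; beyond the scatter) and places compound 2 apart from both compounds with a group para to a large group, so the earlier rise seen for compound 2 cannot be taken as a cost of any change to this aryl group. The data shown offer no measurement that accounts for either step.

Compound 2 differs from compound 4 in both the substituent and where it sits, so the compounds shown do not separate these two changes, and fluoro on the same aromatic carbon as the bromo would be needed to do so. Going by these compounds, it also remains open whether the match between bromo and ethyl extends to a longer chain such as butyl, or to an amine or a carboxylic acid at that place.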